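A few compounds are considered here, and "the series" means these few. Any claim that something is new, unique, unknown or untested is made for them only; others in the source may bear on it.

For the measured compounds named here, compound 3, `CSc1ccc(NC(=O)Nc2cc(C)nc3ccccc23)cc1`, is the only one of three urea analogues with a numerical result in an ADME assay on HEK293 cells (Homo sapiens) for cytotoxicity, with a stated time of 72 h (a higher number here means that more compound is needed for the effect, a lower number that less compound is needed), where compound 3 gives 24000 nM. Compound 1, `Cc1cc(NC(=O)Nc2ccc(C(C)(C)C)cc2)c2ccccc2n1`, gives > 25000 nM in this assay, which is a limit. Compound 2, `Cc1cc(NC(=O)Nc2ccc(Cl)c(Cl)c2)c2ccccc2n1`, likewise gives > 25000 nM, also a limit. Going by the values given here, the one measured step that bears on the new compound, an at least 1.0-fold lower number from compound 1 to compound 3 (0.01 log units; that floor lies within the scatter), lies within the scatter, with the limit of > 25000 nM in this assay, at which 2 of the 3 values shown sit, marking where two of the three values sit. Compound 4, `CCc1ccc(NC(=O)Nc2cc(C)nc3ccccc23)cc1`, differs from compound 3 as follows: ethyl in place of methylsulfanyl on an aromatic carbon. With only a flat step to go on, no change beyond the scatter is expected, so compound 4 is estimated at 25000 nM, in the range 12000 nM to 50000 nM. The expected step is a 1.0-fold higher number from compound 3 to compound 4 (0.02 log units; within the scatter).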

Compound 4, half-maximal effective concentration: 16000 nM
The estimate for compound 4 lay 1.6-fold (0.19 log units) above the measured number; measured number inside the range.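

In this assay, ethyl in place of methylsulfanyl on this aromatic carbon gives a 1.5-fold lower number from compound 3 to compound 4 (0.18 log units; within the scatter), so a change that removes a sulfur and a hydrogen-bond acceptor leaves the number flat. Ethyl in place of tert-butyl at the same place gives an at least 1.5-fold lower number from compound 1 to compound 4 (0.19 log units; that floor lies within the scatter), and that figure is only a floor. Neither step moves the number beyond the scatter, and the top of the range stays hard to read: the limit of > 25000 nM in this assay, at which 2 of the 4 values shown sit.

As far as these compounds go, whether an amine or a carboxylic acid at this position would shift the number beyond the scatter stays open. So does the effect of any change to the shared core.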